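This account rests on a few compounds, and the source may have more. Where it says the series, first, only, none or still open, it means among the compounds named here.

Compound 2 `Cc1c(O)ccc2c1[C@H](Cn1cc(-c3ccccn3)nn1)[C@@]13CC(=O)[C@@](C)(CC[C@@H]21)C3` and compound 1 `Cc1c(O)ccc2c1[C@H](Cn1cc(-c3ccccc3)nn1)[C@@]13CC(=O)[C@@](C)(CC[C@@H]21)C3` share one core, while compound 3 `C=C1C[C@]23C[C@@]1(O)CC[C@@H]2c1cccc(C)c1[C@@H]3Cn1cc(-c2ccccn2)nn1` and the not yet measured compound 4 `C=C1C[C@]23C[C@@]1(O)CC[C@@H]2c1cccc(C)c1[C@@H]3Cn1cc(-c2ccccc2)nn1` share another; the difference between the two cores is not broken down here. In a functional assay on SW480 cells (Homo sapiens) for cytotoxicity, read by MTT assay, with a stated time of 4 days (a higher number here means a weaker inhibitor, a lower number a stronger inhibitor), compound 2 gives only a limit, > 20000 nM. Compound 1 also gives only a limit, > 20000 nM. Compound 3 gives only a limit as well, > 20000 nM. The change phenyl in place of pyridin-2-yl on an aromatic carbon thus yields a step that the two limits leave unreadable from compound 2 to compound 1, because of the limit of > 20000 nM in this assay, at which 3 of the 3 values shown sit. The same change is made from compound 3 to compound 4: phenyl in place of pyridin-2-yl on an aromatic carbon. The step that the limit leaves unreadable from compound 3 to compound 4 is expected to be just as unreadable, resting on (the limit of > 20000 nM in this assay, at which 3 of the 3 values shown sit). Compound 4 is therefore expected to give about 30000 nM in this assay, most probably reported again only as a limit.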

Compound 4, half-maximal inhibitory concentration: > 20000 nM
Compound 4: no number, only a limit; the forecaster's own chance of this, stated with the estimate: 85%; the middle value is on the limit's open side.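

Compound 3 and compound 4 both give only a limit in this assay, so no step between them can be read, because the values give no number: the limit of > 20000 nM in this assay, at which 4 of the 4 values shown sit.

The compounds shown leave open how phenyl and pyridin-2-yl compare on either core.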